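From compound 2 to a 4-methoxyphenyl analogue

The source may hold more compounds than are shown below. What is called first, only, known or untested is meant among the compounds shown, and "the series" means these compounds.

Compound 2 `COc1cc2c(Oc3ccc(NC(=O)c4nn(-c5ccccc5OC(F)(F)F)c(=O)cc4C)cc3F)ccnc2cc1OCCCN1CCCCC1` gives 40 nM in a functional assay on MKN-45 cells (Homo sapiens) for inhibition, read by MTT assay, with a stated time of 72 h (a lower number here means a stronger inhibitor, a higher number a weaker inhibitor), the lowest of the three numbers recorded. Compound 3 `COc1cc2c(Oc3ccc(NC(=O)c4nn(-c5ccccc5OC(F)(F)F)c(=O)cc4C)cc3F)ccnc2cc1OCCCN1CCC(C)CC1` gives 70 nM in this assay, and a 1.8-fold higher number from compound 2 to compound 3 (0.24 log units; within the scatter). Compound 1 `COc1cc2c(Oc3ccc(NC(=O)c4nn(-c5ccccc5C(F)(F)F)c(=O)cc4C)cc3F)ccnc2cc1OCCCN1CCCCC1` gives 90 nM in this assay, and a 2.3-fold lower number from compound 1 to compound 2 (0.35 log units; beyond the scatter).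

Compound 4 `COc1ccc(-n2nc(C(=O)Nc3ccc(Oc4ccnc5cc(OCCCN6CCCCC6)c(OC)cc45)c(F)c3)c(C)cc2=O)cc1` has not yet been measured. It differs from compound 2 in one place: 4-methoxyphenyl in place of 2-(trifluoromethoxy)phenyl on an aromatic nitrogen. Among the measured compounds shown here, the only measured step that touches this aryl group is a 2.3-fold lower number from compound 1 to compound 2 (0.35 log units; beyond the scatter), a modest change from swapping one group for another on an aromatic carbon; the step of a 1.8-fold higher number from compound 2 to compound 3 (0.24 log units; within the scatter) concerns the saturated ring at the other end of the molecule and says nothing about the aryl group. For the measured compounds named here, no measured compound carries a methoxy group on this ring, nor an aryl group that lacks a substituent where compound 1 and compound 2 carry theirs, so the expectation rests on thin ground. The measured step of a 2.3-fold lower number from compound 1 to compound 2 (0.35 log units; beyond the scatter) was itself only modest. The step of a 2.0-fold higher number from compound 2 to compound 4 (0.30 log units; within the scatter) is therefore expected to be small to moderate, most likely toward a higher number, with wide uncertainty. Compound 4 is accordingly estimated at 80 nM in this assay, within a range of 25 nM to 300 nM.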

Compound 4, half-maximal inhibitory concentration: 330 nM
Compound 4: middle estimate off by 4.1-fold (0.62 log units), on the low side; measured number above the stated range.
By their numbers in this assay, from the lowest: compounds 2, 3 and 1 (each within the scatter of the next, the first and the last beyond it); then compound 4.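

Among the compounds shown here, at this place on the aromatic nitrogen, the choice of aryl group matters more than the earlier compounds showed: in this assay, the change from 2-(trifluoromethoxy)phenyl to 4-methoxyphenyl gives an 8.3-fold higher number from compound 2 to compound 4 (0.92 log units; beyond the scatter), a larger step than the only earlier one at this place, a 2.3-fold lower number from compound 1 to compound 2 (0.35 log units; beyond the scatter). The loss is not tied to one reference compound, since the change from 2-(trifluoromethyl)phenyl to 4-methoxyphenyl also gives a step beyond the scatter, a 3.7-fold higher number from compound 1 to compound 4 (0.56 log units; beyond the scatter), so among these three compounds 4-methoxyphenyl is the least favourable group at this place. Nothing among the data available here accounts for the size of this step.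

The change to compound 4 removes one substituent and adds another elsewhere on the ring in a single step, so the compounds shown cannot tell whether the higher number follows from losing the trifluoromethoxy group, from gaining the methoxy group, or from both. An unsubstituted phenyl group on the same nitrogen would separate these two parts of the change, while a pyridyl group would show whether this place accepts anything other than a ring of carbon only.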